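The source may hold more compounds than are shown below. What is called first, only, known or untested is meant among the compounds shown, and "the series" means these compounds.

Measured so far in a physicochemical assay; a lower number here means that less compound is needed, a higher number that more compound is needed for the effect:
compound 1 `COc1cc(/C=N/NC(=O)c2nn(-c3ccc(Cl)cc3Cl)c(-c3ccccc3)c2C)ccc1O`: 2990000 nM
compound 2 `COc1cc(/C=N/NC(=O)c2nn(-c3ccc(F)cc3F)c(-c3ccc(F)cc3)c2C)ccc1O`: 3540000 nM
compound 3 `COc1cc(/C=N/NC(=O)c2nn(-c3ccc(Cl)cc3Cl)c(-c3ccc(C(F)(F)F)cc3)c2C)ccc1O`: 4240000 nM

All three values lie within the usual scatter of one another, so compound 3 cannot be told apart from compound 1 or compound 2. Compared with compound 3, compound 4 `COc1cc(/C=N/NC(=O)c2nn(-c3ccc(F)cc3F)c(-c3ccc(C(F)(F)F)cc3)c2C)ccc1O` has 2,4-difluorophenyl in place of 2,4-dichlorophenyl on an aromatic nitrogen. Among the measured compounds shown here, the only measured step (a 1.4-fold higher number from compound 1 to compound 3 (0.15 log units; within the scatter)) is a different change, trifluoromethyl in place of hydrogen on an aromatic carbon, and it stayed within the scatter. For the measured compounds named here, no measured pair shows the new swap alone. Compound 2 also carries 2,4-difluorophenyl and differs elsewhere too, yet compound 2 gives 3540000 nM within the scatter of compound 3. So in this assay no step beyond the scatter is expected, and the estimated step stays small (a 1.1-fold lower number from compound 3 to compound 4 (0.06 log units; within the scatter)). Compound 4 is estimated at 3700000 nM (expected range 2300000 nM to 5800000 nM).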

Compound 4, half-maximal effective concentration: 2900000 nM
Estimate against measurement, compound 4: 1.3-fold (0.11 log units) above; measured number inside the range.
By their numbers in this assay, from the lowest: compounds 4, 1, 2 and 3 (each within the scatter of the next).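

Read directly in this assay, 2,4-difluorophenyl in place of 2,4-dichlorophenyl on this aromatic nitrogen stays within the scatter (a 1.5-fold lower number from compound 3 to compound 4 (0.16 log units; within the scatter)). With 2,4-difluorophenyl held in place, trifluoromethyl in place of fluoro on an aromatic carbon also stays within the scatter (a 1.2-fold lower number from compound 2 to compound 4 (0.09 log units; within the scatter)). Nothing at hand explains the size of either step.

Still open, on these data alone, is whether a phenyl ring carrying a carboxylic acid or an amine, in place of 2,4-difluorophenyl on this aromatic nitrogen, would give a step beyond the scatter.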